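Benzyl ester of thiophene dihydropyrimidinone: an expected value

The compounds below may be only part of what the source reports. "The series", "measured", "known", "first", "only" and "open" are said of these compounds alone.

Measured compounds:
compound 1 `CC1=C(C(=O)OC(C)(C)C)C(c2ccoc2)NC(=O)N1` with 2%
compound 2 `CC1=C(C(=O)OCc2ccccc2)C(c2ccoc2)NC(=O)N1` with 1%
compound 3 `CC1=C(C(=O)OC(C)(C)C)C(c2cccs2)NC(=O)N1` with 7%

All three were tested in an assay on membranes from HeLa cells for displacement of a labelled ligand from adenosine receptor A3 (Homo sapiens), read by scintillation counting, with a stated time of 180 min, tested at 1 uM; on this read-out higher numbers stand for more inhibition at the one concentration tested (going by the name of the read-out) and lower numbers for less inhibition. Compound 4 `CC1=C(C(=O)OCc2ccccc2)C(c2cccs2)NC(=O)N1` has not been measured there. It differs from compound 3 by benzyl in place of tert-butyl on an oxygen next to a carbonyl group. The same change appears once among the measured compounds, from compound 1 to compound 2: benzyl in place of tert-butyl on an oxygen next to a carbonyl group, where it gave a number 1 percentage points lower from compound 1 to compound 2 (within the scatter). The two places are the same word for word, so the change made from compound 3 to compound 4 is the same change. The cores of compound 1 and compound 3 differ by thiophen-2-yl in place of furan-3-yl on a saturated ring carbon, a change that gave a number 5 percentage points higher from compound 1 to compound 3 (within the scatter).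

Because the earlier step of a number 1 percentage points lower from compound 1 to compound 2 (within the scatter) was small and both cores gave low numbers, the step from compound 3 to compound 4 is expected to be a number 2 percentage points lower from compound 3 to compound 4 (within the scatter). Compound 4 is therefore estimated at 5%, between -5% and 15%.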

Compound 4, a percentage reported as inhibition, at one concentration (the size of the read-out at that concentration, not a potency): 8%
Beside the measured number, compound 4's estimate is 3 percentage points below it; the measured number falls inside the stated range.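

In this assay, benzyl in place of tert-butyl gave a number 1 percentage points higher from compound 3 to compound 4 (within the scatter), and the two cores agree on this change: the same change on two cores in this assay, a number 1 percentage points lower (within the scatter) from compound 1 to compound 2 and a number 1 percentage points higher (within the scatter) from compound 3 to compound 4, 2 percentage points apart, within the scatter of two such steps

Thiophen-2-yl in place of furan-3-yl gave a number 7 percentage points higher from compound 2 to compound 4 (within the scatter), and this change also agrees across the two cores: the same change on two cores in this assay, a number 5 percentage points higher (within the scatter) from compound 1 to compound 3 and a number 7 percentage points higher (within the scatter) from compound 2 to compound 4, 2 percentage points apart, within the scatter of two such steps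

Going by these compounds alone, all four compounds give low numbers at the one concentration tested, so the agreement shows only that neither change moved the number beyond the scatter on these cores, not that either change would carry over in the same way on a core with a high number.

The compounds shown leave open what a longer chain in place of benzyl or tert-butyl, or such a chain carrying an amine or a carboxylic acid, would give in this assay.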